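The source may hold more compounds than are shown below. What is called first, only, known or untested is meant among the compounds shown, and "the series" means these compounds.

Of the compounds shown here, two built on the same core have been measured in an assay on mitochondria from L6 cells (Rattus norvegicus) for activation, with a stated time of 90 min; a higher number here means that more compound is needed for the effect, a lower number that less compound is needed. Among the compounds with values here, compound 1 `Oc1nc2nonc2nc1Nc1ccccc1` gives 66700 nM, the highest of the two numbers so far. Compound 2 `Oc1nc2nonc2nc1Nc1ccccc1C(F)(F)F` gives 10600 nM. Within the data shown here, the single measured step, a 6.3-fold lower number from compound 1 to compound 2 (0.80 log units; beyond the scatter), is the only guide available, and it concerns the same kind of group that enters in the new compound.

Compound 3 `Oc1nc2nonc2nc1Nc1ccc(C(F)(F)F)cc1` differs from compound 1 by trifluoromethyl in place of hydrogen on an aromatic carbon. Among the measured compounds shown here, the entering group is the one already seen in compound 2, but here it sits at another place on the ring, and no measured compound shows what that place does. The step from compound 1 to compound 2 therefore bears on the new compound only in part: a change in the same direction is expected, while its size is less certain. Compound 3 is expected to need less compound than compound 1, by a step of a 4.4-fold lower number from compound 1 to compound 3 (0.65 log units; beyond the scatter). The estimate for compound 3 in this assay is 15000 nM, expected to lie between 4000 nM and 50000 nM.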

Compound 3, half-maximal effective concentration: 10400 nM
The estimate for compound 3 lay 1.4-fold (0.16 log units) above the measured number; the range from low to high includes it.
By their numbers in this assay, from the lowest: compounds 3 and 2 (each within the scatter of the next); then compound 1.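

Putting trifluoromethyl on an aromatic carbon para to a large group also lowers the number in this assay, with a 6.4-fold lower number from compound 1 to compound 3 (0.81 log units; beyond the scatter), so the drop seen so far is not confined to the single ring place occupied in compound 2. In the same read-out compound 2 gives 10600 nM and compound 3 gives 10400 nM, and these numbers lie within the usual scatter of each other, so in this pair the place of the group on the ring makes no difference that can be read. No measurement shown here explains why the group has this effect at either place.

Going by these compounds, it remains open whether the lower number belongs to trifluoromethyl in particular or would also come with another group at the same place, such as a chlorine atom, a methoxy group or an amine. On these data alone, it also remains open what the other places on the ring would give, and whether two trifluoromethyl groups on one ring would lower the number further.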